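Methoxy removal in an enaminone series, toward compound 3

A few compounds are considered here, and "the series" means these few. Any claim that something is new, unique, unknown or untested is made for them only; others in the source may bear on it.

Measured compounds: compound 1, `O=C(/C=C\Nc1cnc2ccccc2c1)c1nc(-c2ccccc2)n2ccccc12`, > 30000 nM. Compound 2, `COc1ccc(N/C=C\C(=O)c2nc(-c3ccc(OC)cc3)n3ccccc23)cc1`, "not determined" (no result reported).

Compound 1 was measured in a functional assay on A549 cells (Homo sapiens) for cytotoxicity, read by MTT assay, with a stated time of 48 h (a lower number here means a stronger inhibitor, a higher number a weaker inhibitor), and the reading for compound 1 is a limit of the assay, > 30000 nM, not a number. For compound 2 the result in this assay stands as "not determined" (no result reported), so no single number places compound 2 anywhere. The only anchor among the measured compounds is the limit of > 30000 nM in this assay, at which 1 of the 2 values shown sits, where compound 1 sits. Compound 3, `COc1ccc(N/C=C\C(=O)c2nc(-c3ccccc3)n3ccccc23)cc1`, has not been measured in this assay. Compound 3 differs from compound 2 by hydrogen in place of methoxy on an aromatic carbon. Among the measured compounds shown here, no step between measured compounds is known, so the size and direction of any shift from compound 2 to compound 3 cannot be read from the data; with a single heavy-atom pair leaving, a change beyond the scatter is not expected in either direction. Given that compound 1 in this assay returned only > 30000 nM, compound 3 is expected to sit at about 30000 nM, within 8000 nM to 100000 nM, with a real chance that it too is reported only as a limit.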

Compound 3, half-maximal inhibitory concentration: > 30000 nM
Compound 3: no number, only a limit; the forecaster's own chance of this, stated with the estimate: 60%; the middle value sits exactly at the limit.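

In this assay compound 3 gives only a limit, as compound 1 does, so no step can be read between compound 1 and compound 3; with no number for compound 2, none can be read between compound 2 and compound 3 either. The compounds shown leave open whether 4-methoxyphenyl to phenyl shifts the reading in this assay at all, and in which direction.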